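This account rests on a few compounds, and the source may have more. Where it says the series, first, only, none or still open, it means among the compounds named here.

Measured so far in a physicochemical assay for lipophilicity, read by HPLC, at pH 7.5; on this read-out higher numbers stand for higher lipophilicity and lower numbers for lower lipophilicity:
- compound 1 `CC[C@@H](Nc1c(C#N)c(-c2ccc(-c3ccncc3C)cc2)nc2cnccc12)C(N)=O` gives 2
- compound 2 `CC[C@@H](Nc1c(C#N)c(-c2ccc(Br)cc2)nc2cnccc12)C(=O)O` gives 1.6
- compound 3 `CCOc1ccccc1-c1ccc(-c2nc3cnccc3c(NC(C(N)=O)C3CC3)c2C#N)cc1` gives 3

Compound 1 stands second highest of the three numbers in this assay. Its nearest neighbour is compound 2, whose number lies lower, beyond the scatter; compound 3 lies furthest away, with a number higher than compound 1, again beyond the scatter. None of these pairs differs in a single place, so no single change can be tied to any of these gaps.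

Compound 4 `CC[C@@H](Nc1c(C#N)c(-c2ccc(-c3ccccc3C(F)(F)F)cc2)nc2cnccc12)C(N)=O` is not yet measured. It differs from compound 1 in one place: 2-(trifluoromethyl)phenyl in place of 3-methylpyridin-4-yl on an aromatic carbon. The group that leaves carries one hydrogen-bond acceptor and a ring with one hetero atom; the group that enters carries none and a ring of carbon only, with three fluorine atoms in its 2-(trifluoromethyl) substituent, on an aromatic carbon para to a large group.

With no measured step of this kind in the series, the direction rests on the structural change alone. A rise in this assay is expected, beyond the scatter, of a size roughly comparable to the gap between compound 1 and compound 3. The expected step is a number 1.40 log units higher from compound 1 to compound 4 (beyond the scatter). Compound 4 is estimated to give 3.4, within a range from 2.9 to 3.9.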

Compound 4, distribution coefficient: 3.1
Compound 4: middle estimate off by 0.30 log units, on the high side; the range from low to high includes it.
By their numbers in this assay, from the lowest: compound 2; then compound 1; then compounds 3 and 4 (each within the scatter of the next).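

On the aromatic carbon para to a large group, the series now has its first comparison that differs in one place: in this assay, 2-(trifluoromethyl)phenyl in place of 3-methylpyridin-4-yl gives a number 1.10 log units higher from compound 1 to compound 4 (beyond the scatter), a large step. Going by these compounds alone, this shows that the read-out responds strongly to the group at this carbon, which the earlier compounds, differing in several places at once, could not show. The change is still a bundle, since the ring hetero atom and its hydrogen-bond acceptor leave while three fluorine atoms enter, and no evidence at hand accounts for the size of the step.

A plain phenyl or a 2-methylphenyl at this carbon would separate the share of the ring nitrogen from that of the trifluoromethyl group, which this single step cannot do. From the compounds shown here alone, it also remains open how far the number would move with a group of another kind here, such as an aminomethyl or a morpholine, and whether the step keeps its size when the amide side chain of compound 1 is changed.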